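The source may hold more compounds than are shown below. What is called first, only, known or untested is meant among the compounds shown, and "the series" means these compounds.

Measured in an ADME assay on HaCaT cells (Homo sapiens) for cytotoxicity, read by MTT assay, with a stated time of 48 h; a higher number here means a weaker inhibitor, a lower number a stronger inhibitor:
Compound 1 `O=C(OCc1ccccc1)c1ccc2[nH]c(-c3cn(-c4ccccc4)nc3-c3ccccc3)nc2c1` gives > 50000 nM as a limit
Compound 2 `COc1ccc(-c2nn(-c3ccccc3)cc2-c2nc3cc(F)ccc3[nH]2)cc1` gives > 50000 nM as a limit
Compound 3 `COc1ccc(-c2nn(-c3ccccc3)cc2-c2nc3cc(C(F)(F)F)ccc3[nH]2)cc1` gives > 50000 nM as a limit

Compound 3 gives only a limit, > 50000 nM and so has no ranked place in the series. The evidence so far amounts to the limit of > 50000 nM in this assay, at which 3 of the 3 values shown sit, and nothing more. Compound 4 `COc1ccc(-c2nn(-c3ccccc3)cc2-c2nc3cc(C(=O)OCc4ccccc4)ccc3[nH]2)cc1` carries benzyloxycarbonyl in place of trifluoromethyl on an aromatic carbon, counted as benzyloxycarbonyl in place of trifluoromethyl on an aromatic carbon and otherwise matches compound 3. Among the measured compounds shown here, the one measured step is a step that the two limits leave unreadable from compound 2 to compound 3 and gives no size to carry over. Compound 1 also carries benzyloxycarbonyl and gives > 50000 nM as a limit. No step beyond the scatter is therefore expected in this assay and the estimated a number no higher from compound 3 to compound 4 (the limit leaves the size open) remains an expectation only. Compound 4 is expected at 50000 nM with an estimated range from 25000 nM to 100000 nM and will probably be reported as a limit again.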

Compound 4, half-maximal inhibitory concentration: > 50000 nM
Compound 4: only a limit was reported; the forecaster's own chance of this, stated with the estimate: 85%; the middle value sits exactly at the limit.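

The steps from compound 1, compound 2 and compound 3 to compound 4 cannot be read in this assay, as each value is only a limit: the limit of > 50000 nM in this assay, at which 4 of the 4 values shown sit. The compounds shown leave open how large any of these steps is and whether any of the changes matters at all.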